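The source may report more compounds than this note shows. Statements on the series, on what has been measured and on what is new or still open speak of the compounds shown alone.

Values in a functional assay on OVCAR-3 cells (Homo sapiens) for antiproliferative activity, read by WST assay, with a stated time of 72 h, in the absence of a further agent; a lower number here means a stronger inhibitor, a higher number a weaker inhibitor:
- compound 1 `CCCCCCCC/C=C\c1c(C)c(/C=C\CCCCCCCC)c2[n+](c1C)CCC2`: 1100 nM
- compound 2 `CCCCCCCC/C=C/c1c(C)c(/C=C/CCCCCCCC)c2[n+](c1C)CCC2`: 800 nM
- compound 3 `CCCCCCCC/C=C\c1c(C)c(/C=C/CCCCCCCC)c(C)[n+]2c1CCC2`: 900 nM

Compounds 1, 2 and 3 have the same atoms and bonds and differ only in how their two double bonds are drawn. Compound 3 has no real separation from the other two. The steps are a 1.2-fold lower number from compound 1 to compound 3 (0.09 log units; within the scatter) and a 1.1-fold higher number from compound 2 to compound 3 (0.05 log units; within the scatter), and the remaining pair shows a 1.4-fold lower number from compound 1 to compound 2 (0.14 log units; within the scatter). Among these three compounds, then, double-bond geometry leaves the number unchanged within the scatter.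

Compound 4 `CCCCCCCC/C=C\c1c(C)cc(C)[n+]2c1CCC2` brings a different kind of change: a hydrogen atom in place of a group of 10 heavy atoms (10 carbon; no ring), on an aromatic carbon. One whole chain is gone, and the dec-1-en-1-yl group remains as the only long chain. The three measured steps bear on this only weakly, since none of them removes a chain. They show how little geometry matters, not what losing a chain does. The starting point is therefore compound 3 at 900 nM. This edit is far larger than any measured so far, so a step beyond the scatter seems likely, though its direction is a judgement. The expected step is a 3.3-fold higher number from compound 3 to compound 4 (0.52 log units; beyond the scatter), towards a weaker inhibitor. Compound 4 is estimated at 3000 nM, with an expected range from 800 nM to 12000 nM.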

Compound 4, half-maximal inhibitory concentration: 1300 nM
The estimate for compound 4 lay 2.3-fold (0.36 log units) above the measured number; the range from low to high includes it.
By their numbers in this assay, from the lowest: compounds 2, 3, 1 and 4 (each within the scatter of the next).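

In this assay, replacing the dec-1-en-1-yl group with hydrogen on this aromatic carbon, two atoms from the ring nitrogen, removes a whole long chain, yet the step is only a 1.4-fold higher number from compound 3 to compound 4 (0.16 log units; within the scatter), and the comparison with the other Z-drawn partner gives a 1.2-fold higher number from compound 1 to compound 4 (0.07 log units; within the scatter). The earlier compounds shown here all carried two long chains and differed only in double-bond geometry, so they could not show this: a second long chain is not needed to keep the number within the scatter of these two neighbours, and one dec-1-en-1-yl group on the shared core is enough here. The available evidence concerns only how the double bonds are drawn and offers no explanation for this result.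

On these data alone, whether this carbon tolerates anything other than hydrogen or a dec-1-en-1-yl group remains open, for example a carboxylic acid, an amine or a shorter chain such as hexyl. Also open, as far as these compounds go, is what happens when the remaining dec-1-en-1-yl group is replaced as well, leaving the core with no long chain at all.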